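The source may report more compounds than this note shows. Statements on the series, on what has been measured and on what is new or still open speak of the compounds shown alone.

The shared core carries, on one of its aromatic rings, a nitrogen that is joined to either a urea or an amide. Compound 1 `COc1cc(-c2nn(-c3cccc(NC(=O)Nc4ccc(Cl)c(Cl)c4)c3)cc2-c2ccncc2)ccc1Cl` has a urea ending in a (3,4-dichlorophenyl)amino group, and in a functional assay on UO-31 cells (Homo sapiens) for inhibition, read by sulforhodamine B assay, with a stated time of 48 h (a higher number here means a weaker inhibitor of growth, a lower number a stronger inhibitor of growth), compound 1 gives 4980 nM. Compound 3 `COc1cc(-c2nn(-c3cccc(NC(=O)Nc4ccc(Cl)c(C(F)(F)F)c4)c3)cc2-c2ccncc2)ccc1Cl` keeps the urea but carries a (4-chloro-3-(trifluoromethyl)phenyl)amino group on the carbonyl carbon; in this assay compound 3 gives 4100 nM, the lowest of the two plain numbers measured, although the step of a 1.2-fold lower number from compound 1 to compound 3 (0.08 log units; within the scatter) lies within the scatter. Compound 2 `COc1cc(-c2nn(-c3cccc(NC(=O)c4ccc(Cl)c(C(F)(F)F)c4)c3)cc2-c2ccncc2)ccc1Cl` is the amide that matches compound 3. In this assay compound 2 reaches only a limit of the assay, > 32500 nM. Replacing that amide by the urea gives an at least 7.9-fold lower number from compound 2 to compound 3 (0.89 log units; beyond the scatter), and the step of an at least 6.5-fold higher number from compound 1 to compound 2 (0.81 log units; beyond the scatter) points the same way. Compound 4 `COc1cc(-c2nn(-c3cccc(NC(=O)c4ccccc4)c3)cc2-c2ccncc2)ccc1Cl` returns to an amide: phenyl in place of (4-chloro-3-(trifluoromethyl)phenyl)amino on a carbonyl carbon. The only measured amide, compound 2, sat at the limit (the limit of > 32500 nM in this assay, at which 1 of the 3 values shown sits), so a clearly higher number than compound 3 is expected for compound 4, very possibly again a limit. Compound 4 is expected to give about 30000 nM in this assay, with a range from 9000 nM to 100000 nM. That estimate means a step of a 7.3-fold higher number from compound 3 to compound 4 (0.86 log units; beyond the scatter).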

Compound 4, concentration for total growth inhibition: > 100000 nM
Compound 4: a limit, no number (the forecaster's own chance of this, stated with the estimate: 60%); middle value at least 3.3-fold (0.52 log units) away from the limit.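

Compound 4 also gives no plain number in this assay, only a limit: the limit of > 100000 nM in this assay, at which 1 of the 4 values shown sits. Against the two ureas, the gap is large, with an at least 24-fold higher number from compound 3 to compound 4 (1.38 log units; beyond the scatter) and an at least 20-fold higher number from compound 1 to compound 4 (1.30 log units; beyond the scatter), so a second amide, this one ending in a bare phenyl, now lies on the weak side of both ureas, where compound 2 alone stood before. Both amides end at limits, so the step between compound 2 and compound 4 cannot be read, and nothing shows whether the chloro and trifluoromethyl groups on the amide's ring change the result: the limit of > 32500 nM in this assay, at which 1 of the 4 values shown sits.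

Every urea shown also carries a chlorine and a second substituent on its end ring, which leaves open how a urea ending in a plain phenylamino group would compare with compound 4, the one change that would test the urea apart from those ring substituents. Also open, as far as these compounds go, is how other links at the same nitrogen, such as a carbamate or a sulfonamide, would rank against the ureas and the amides in this assay.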